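This account rests on a few compounds, and the source may have more. Where it says the series, first, only, none or still open, it means among the compounds named here.

Measured compounds in a functional assay on HCT-116 cells (Homo sapiens) for antiproliferative activity, read by MTT assay, with a stated time of 48 h; a higher number here means a weaker inhibitor, a lower number a stronger inhibitor:

compound 1, `CC(=O)Nc1ccc(-n2nncc2CN2C(=O)C3(C(C#N)=C(N)Oc4c(N)cc5nc6ccccc6nc5c43)c3ccccc32)cc1` — compound 1 gives > 50000 nM, a limit of the assay
compound 2, `N#CC1=C(N)Oc2c(N)cc3nc4ccccc4nc3c2C12C(=O)N(Cc1cnnn1-c1c(F)cccc1F)c1ccccc12` — compound 2 gives > 50000 nM, a limit of the assay

Compound 2 stands at the limit of this assay: the value of compound 2 in this assay is a limit and not a number. For the measured compounds named here, the only measured step, a step that the two limits leave unreadable from compound 1 to compound 2, runs between two limits and its size cannot be read; the limit of > 50000 nM in this assay, at which 2 of the 2 values shown sit, is all the evidence on it.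

Compound 3, `Cc1ccc(Cl)cc1-n1nncc1CN1C(=O)C2(C(C#N)=C(N)Oc3c(N)cc4nc5ccccc5nc4c32)c2ccccc21`, differs from compound 2 in one place: 5-chloro-2-methylphenyl in place of 2,6-difluorophenyl on an aromatic nitrogen. Going by the values given here, the step that bears on this change is the unreadable one from compound 1 to compound 2, which shows only that both aryl groups on the triazole nitrogen leave the activity at the limit. Among the compounds with values here, no measured step gives a direction or size for the new aryl group, so no change beyond the scatter can be claimed; a further limit is the most likely outcome.

Compound 3 is therefore expected to sit near the limit again, at an estimated 60000 nM with a range from 20000 nM to 200000 nM in this assay. The step from compound 2 to compound 3 that this estimate means, a step that the limit leaves unreadable from compound 2 to compound 3, is expected to be within scatter.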

Compound 3, half-maximal inhibitory concentration: 37200 nM
Beside the measured number, compound 3's estimate is 1.6-fold (0.21 log units) above it, within the range that was stated.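

In this assay, for the compounds shown here, the 5-chloro-2-methylphenyl group gives the first value on this aromatic nitrogen that is a number and not a limit, so the readable range of the assay can be reached by changing this aryl group alone on the shared core. The gain cannot be sized, however: the change gives an at least 1.3-fold lower number from compound 2 to compound 3 (0.12 log units; that floor lies within the scatter), and replacing 4-acetamidophenyl gives an at least 1.3-fold lower number from compound 1 to compound 3 (0.12 log units; that floor lies within the scatter), so neither step establishes a change beyond the scatter. The step between the two earlier aryl groups cannot be read, and the limit remains the main feature of the compounds shown: the limit of > 50000 nM in this assay, at which 2 of the 3 values shown sit.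

It remains open whether the chlorine or the methyl matters more, as the compounds shown include no phenyl group carrying only one of them. From the compounds shown here alone, it also remains open whether a different kind of group on this nitrogen, such as a longer alkyl chain or a phenyl group bearing an amine or a carboxylic acid, would give a value clearly separated from the limit.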